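A few compounds are considered here, and "the series" means these few. Any claim that something is new, unique, unknown or untested is made for them only; others in the source may bear on it.

Compound 2 `CCOC(=O)c1cn(C(c2ccccc2)c2cc3cc(Br)ccc3nc2OC)nn1` gives 15.4% in an ADME assay on PANC-1 cells (Homo sapiens) for cytotoxicity, read by sulforhodamine B assay, with a stated time of 48 h, tested at 10 uM (a lower number here means less inhibition, a higher number more inhibition at the concentration tested (going by the name of the read-out)), and on the numbers shown it stands within the usual scatter of compound 1 `COc1nc2ccc(Br)cc2cc1C(c1ccccc1)n1cc(-c2ccccc2F)nn1`, which gives 14.7%. Compound 3 `CCCc1cn(C(c2ccccc2)c2cc3cc(Br)ccc3nc2OC)nn1` differs from compound 2 by propyl in place of ethoxycarbonyl on an aromatic carbon. Going by the values given here, one measured step bears on this: the change a number 0.7 percentage points higher from compound 1 to compound 2 (within the scatter) at the same aromatic carbon stayed within the scatter, so a swap of the group there has so far moved this assay little. Compound 3 is therefore expected to show no step beyond the scatter, a number 0.4 percentage points lower from compound 2 to compound 3 (within the scatter). The estimated value of compound 3 is 15%, with a range from 4% to 28%.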

Compound 3, a percentage reported as inhibition, at one concentration (the size of the read-out at that concentration, not a potency): 11.3%
Beside the measured number, compound 3's estimate is 3.7 percentage points above it; measured number inside the range.
By their numbers in this assay, from the lowest: compounds 3, 1 and 2 (each within the scatter of the next).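

In this assay propyl in place of ethoxycarbonyl gives a number 4.1 percentage points lower from compound 2 to compound 3 (within the scatter) and propyl in place of 2-fluorophenyl gives a number 3.4 percentage points lower from compound 1 to compound 3 (within the scatter) at the same aromatic carbon of the five-membered aromatic ring with 3 nitrogen. Three groups now stand at this carbon, among them propyl with no hydrogen-bond acceptors and no ring, and none separates from the others beyond the scatter. No measurement here offers an explanation for this. From the compounds shown here alone, whether an amine, a carboxylic acid or a longer chain at this carbon would give a step beyond the scatter stays open.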